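Hydroxy for pyrrolyl on a cyanovinyl diaryl series

This account rests on a few compounds, and the source may have more. Where it says the series, first, only, none or still open, it means among the compounds named here.

Measured so far:
compound 1, `CCOc1cc(C(=CC#N)c2ccc(OC)c(-n3cccc3)c2)ccc1OC`: 49 nM
compound 2, `C=C(c1ccc(OC)c(N)c1)c1ccc(OC)c(OCC)c1`: 38 nM
compound 3, `C=C(c1cc(OC)cc(OC)c1)c1ccc(OC)c(O)c1`: 21 nM

All three were run in a functional assay on HCT-116 cells (Homo sapiens) for cytotoxicity, read by scintillation counting and thymidine incorporation, with a stated time of 72 h; a lower number here means a stronger inhibitor, a higher number a weaker inhibitor. Compound 1 gives 49 nM, the highest of the three numbers. Compound 2 gives 38 nM, and the gap from compound 1 to compound 2 is within the scatter, so no order can be drawn between them. Compound 3 gives 21 nM, and its gap to compound 1 is beyond the scatter. Compound 3 differs from compound 1 in more than one place, so no single change can be tied to that gap.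

Compound 4, `CCOc1cc(C(=CC#N)c2ccc(OC)c(O)c2)ccc1OC`, has not yet been measured in this assay. It differs from compound 1 in one place: hydroxy in place of 1H-pyrrol-1-yl on an aromatic carbon. Compound 3 also carries a hydroxy ortho to a methoxy group and gives 21 nM, which is the only hint available, and it is an indirect one.

A modest step toward a lower number, or none beyond the scatter, is expected here. The step of a 1.6-fold lower number from compound 1 to compound 4 (0.21 log units; within the scatter) is the estimate for this change. Compound 4 is expected at about 30 nM, with a range of 12 nM to 75 nM.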

Compound 4, half-maximal inhibitory concentration: 15 nM
Beside the measured number, compound 4's estimate is 2.0-fold (0.30 log units) above it, within the range that was stated.
By their numbers in this assay, from the lowest: compounds 4, 3, 2 and 1 (each within the scatter of the next, the first and the last beyond it).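

In this assay, among these compounds, the change from 1H-pyrrol-1-yl to hydroxy on this aromatic carbon, ortho to a methoxy group, gives a 3.3-fold lower number from compound 1 to compound 4 (0.51 log units; beyond the scatter) and is the first single-place comparison. The position therefore does not need the five-membered aromatic ring for a low number: a group of 1 heavy atom, in place of one with 5 heavy atoms, gives the lower number here, and it also brings 1 hydrogen-bond donor where the pyrrolyl group has 0. No measurement at hand accounts for the step, so this pair shows its size and direction but not its origin.

Among the compounds shown here, the single change removes the ring and adds the donor together, so the pair cannot separate the two, and a methyl group, a fluorine atom or a carboxylic acid on the same aromatic carbon would be needed to tell them apart. For the compounds shown here, also open is whether the same exchange gives a similar step on a core without the nitrile, since this one pair is the only direct comparison available.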